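Ester variation on the shared core: compound 3 to compound 4

This account rests on a few compounds, and the source may have more. Where it says the series, first, only, none or still open, it means among the compounds named here.

Of the compounds shown here, three have been measured in a functional assay on HEK293 cells for antagonist activity at Voltage-dependent L-type calcium channel subunit alpha-1C (Oryctolagus cuniculus), read by FLIPR; on this read-out higher numbers stand for weaker inhibition and lower numbers for stronger inhibition. Compound 1 `CCOC(=O)C1=C(C)NC(COC)=C(C(=O)OC)C1c1cccc([N+](=O)[O-])c1` gives 14 nM, compound 2 `C=CCOC(=O)C1=C(C)NC(C)=C(C(=O)OCC)C1c1cccc([N+](=O)[O-])c1` gives 25 nM, and compound 3 `COC(=O)C1=C(C)NC(C)=C(C(=O)OC2C=CCCC2)C1c1cccc([N+](=O)[O-])c1` gives 10 nM. Compound 3 carries the lowest of the three numbers. Its gap to compound 1 lies within the usual scatter of repeated measurements, so no order between these two can be drawn. Its gap to compound 2 lies beyond the scatter, so compound 3 inhibits more strongly than compound 2 in this assay.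

Compound 4 `COC(=O)C1=C(C)NC(C)=C(C(=O)OCCOCc2ccccc2)C1c1cccc([N+](=O)[O-])c1` has not yet been measured. It differs from compound 3 in one place: 2-(benzyloxy)ethyl in place of cyclohex-2-en-1-yl on an oxygen next to a carbonyl group. The measured compounds already vary in their ester groups, and the numbers stay close together, so no step beyond the scatter is expected here in either direction. Compound 4 is estimated at 15 nM, with a range from 5 nM to 45 nM. The step of a 1.5-fold higher number from compound 3 to compound 4 (0.18 log units; within the scatter) is expected to fall within the scatter, because the ester changes among compound 1 at 14 nM, compound 2 at 25 nM and compound 3 at 10 nM move the number only little. Whether the 2-(benzyloxy)ethyl group in place of cyclohex-2-en-1-yl behaves the same way remains to be seen.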

Compound 4, half-maximal inhibitory concentration: 9 nM
For compound 4 the middle estimate is 1.7-fold (0.22 log units) above the measured one; the measured number falls inside the stated range.
By their numbers in this assay, from the lowest: compounds 4, 3, 1 and 2 (each within the scatter of the next, the first and the last beyond it).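

In this assay, within the data shown here, the change of 2-(benzyloxy)ethyl in place of cyclohex-2-en-1-yl on an oxygen next to a carbonyl group gives a 1.1-fold lower number from compound 3 to compound 4 (0.05 log units; within the scatter), the first step that can be read at a single place, since the earlier compounds differ from one another in more than one place. The exchange is not a small one: the group that enters holds more heavy atoms than the group that leaves, a non-aromatic carbon ring with its double bond gives way to an aromatic ring on a chain, and a hydrogen-bond acceptor is added, yet the number stays within the scatter, so for this pair the place accepts both groups without a readable difference. No measurement shown here accounts for this outcome.

The compounds shown leave open whether an ester chain ending in an amine or a carboxylic acid in place of the benzyl ether would keep the number in this range. They also leave open whether a longer chain between the ester oxygen and the phenyl ring, or the same exchange made on a compound carrying an ethyl ester instead of the methyl ester, would give a similarly small step.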